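Working notes: from 4-fluorophenoxy to ethoxy

The source may report more compounds than this note shows. Statements on the series, on what has been measured and on what is new or still open speak of the compounds shown alone.

In a functional assay on PC-3 cells (Homo sapiens) for inhibition, read by sulforhodamine B assay, with a stated time of 48 h, tested at 50 uM (a lower number here means less inhibition of growth, a higher number more inhibition of growth at the concentration tested), compound 2 (`COc1cc2c(cc1CC=C(C)C)C(=O)C[C@@H](c1ccc(Oc3ccc(F)cc3)cc1)O2`) gives 19% and stands lowest of the three measured compounds. Compound 3 (`COc1ccc([C@@H]2C/C(=N/OCc3cn(-c4cccc(CO)c4)nn3)c3cc(CC=C(C)C)c(OC)cc3O2)cc1`) gives 34% in the same test and compound 1 (`COc1cc2c(cc1CCC(C)C)C(=O)C[C@@H](c1ccc(O)cc1)O2`) gives 78% at the top. Both gaps to compound 2 lie beyond the usual scatter. Going by the values given here, no two measured compounds differ in one place only, so the series offers no direct precedent for a single change.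

Compound 4 (`CCOc1ccc([C@@H]2CC(=O)c3cc(CC=C(C)C)c(OC)cc3O2)cc1`) departs from compound 2 in one place: ethyl in place of 4-fluorophenyl on an oxygen on an aromatic ring. Compound 3 at 34% and compound 1 at 78% carry no 4-fluorophenoxy group and both read higher than compound 2, though they also differ from it elsewhere. A rise beyond the scatter is therefore expected in this assay, with wide uncertainty. The expected step is a number 26 percentage points higher from compound 2 to compound 4 (beyond the scatter) (an estimate only). In this assay the estimate for compound 4 is 45% (expected range 20% to 72%).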

Compound 4, percent growth inhibition at one concentration: 60%
Compound 4: the middle estimate sits 15 percentage points below what was measured, within the range that was stated.
By their numbers in this assay, from the lowest: compound 2; then compound 3; then compound 4; then compound 1.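

In this assay, going by these compounds alone, the series now has its first comparison in which only one place changes: ethyl in place of 4-fluorophenyl on an oxygen on an aromatic ring gives a number 41 percentage points higher from compound 2 to compound 4 (beyond the scatter) with the rest of the structure unchanged. The group on this oxygen therefore affects the read-out by itself, and of the two groups compared here, ethyl goes with more inhibition of growth. Nothing available explains the size of this step.

With only these two groups compared at this oxygen, the compounds shown do not separate the loss of the fluorine from the loss of the whole aromatic ring. A plain phenyl would address that question, while methyl, a longer chain such as butyl, or a 2-aminoethyl group would show how far the step depends on the group's length and atoms.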